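The source may report more compounds than this note shows. Statements on the series, on what has been measured and on what is new or still open speak of the compounds shown alone.

In a functional assay on cells (Panel leukemia (Carcinoma cell lines), Homo sapiens) for inhibition (on this read-out lower numbers stand for stronger inhibition of growth and higher numbers for weaker inhibition of growth), compound 1 (`Cc1ccc(/C=C2\CN(C)CC3=C2N=C(S)NC3c2ccc(C)cc2)cc1`) gives 19200 nM and compound 2 (`CN1C/C(=C\c2cccs2)C2=NN(C)C(c3cccs3)C2C1`) gives 31800 nM, so the two values lie within the scatter of each other. Compound 3 (`CN1C/C(=C\c2cccs2)C2=NN(c3ccccc3)C(c3cccs3)C2C1`) keeps the core of compound 2 but has phenyl in place of methyl on an amine nitrogen in a ring. Going by the values given here, no measured step in this assay shows what this exchange does, so only a modest gain in growth inhibition is expected, and possibly none beyond the scatter. The expected change is a 2.1-fold lower number from compound 2 to compound 3 (0.33 log units; beyond the scatter). Compound 3 is estimated at 15000 nM, with an expected range of 4500 nM to 45000 nM.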

Compound 3, concentration for 50% growth inhibition: 2200 nM
Compound 3: the middle estimate sits 6.8-fold (0.83 log units) above what was measured, and the stated range ends above it.
By their numbers in this assay, from the lowest: compound 3; then compounds 1 and 2 (each within the scatter of the next).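

In this assay, going by these compounds alone, the step from methyl to phenyl on the amine nitrogen in a ring gives a 14-fold lower number from compound 2 to compound 3 (1.16 log units; beyond the scatter) and so shows that this position strongly affects growth inhibition, which no earlier pair could show. The gain comes with a six-membered aromatic ring of carbon only and no added hydrogen-bond donors or acceptors. No evidence on the cause of this step is at hand. The compounds shown leave open whether the gain needs an aromatic ring, which a cyclohexyl group on the same nitrogen would test. They also leave open whether a pyridyl or chlorophenyl group there would give a stronger or weaker effect.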